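Adding a hydroxymethyl to the dimethylamide

The source may hold more compounds than are shown below. What is called first, only, known or untested is meant among the compounds shown, and "the series" means these compounds.

Among the measured compounds shown here, compound 2 `CN(C)C(=O)/C=C/c1ccccc1` is one of two compounds measured in a functional assay on the whole organism (strain Kunming) with Mus musculus as the target, in the forced swim test, with a stated time of 30 min, at a dose of 10 mg/kg by the intraperitoneal route; on this read-out lower numbers stand for less inhibition and higher numbers for more inhibition at the one dose given (going by the name of the read-out). Compound 2 gives 20%, while compound 1 `O=C(/C=C/c1ccccc1)NCCCO` gives 23.4%; the step of a number 3.4 percentage points lower from compound 1 to compound 2 (within the scatter) lies within the scatter, so the two numbers stand together. Compound 3 `CN(CCO)C(=O)/C=C/c1ccccc1` differs from compound 2 by hydroxymethyl in place of hydrogen on a saturated chain carbon bound to an amide-type nitrogen. For the measured compounds named here, the only step that bears on it, a number 3.4 percentage points lower from compound 1 to compound 2 (within the scatter), also altered the substituents on the amide-type nitrogen and stayed within the scatter, so no movement beyond the scatter is expected in this assay. Compound 3 is therefore estimated to give 21%, in the range 12% to 30%. That estimate means a step of a number 1 percentage points higher from compound 2 to compound 3 (within the scatter).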

Compound 3, a percentage reported as inhibition, in the whole organism at one dose (the size of the read-out at that dose, not a potency): 8.41%
Beside the measured number, compound 3's estimate is 12.6 percentage points above it; measured number outside the range, below it.
By their numbers in this assay, from the lowest: compound 3; then compounds 2 and 1 (each within the scatter of the next).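

Hydroxymethyl in place of hydrogen on a saturated chain carbon bound to an amide-type nitrogen gives a number 11.6 percentage points lower from compound 2 to compound 3 (beyond the scatter) in this assay and is the first single change here to pass the scatter. (2-Hydroxyethyl)(methyl)amino in place of (3-hydroxypropyl)amino on a carbonyl carbon gives a number 15 percentage points lower from compound 1 to compound 3 (beyond the scatter) as well, so carrying a hydroxyl-bearing chain on the amide-type nitrogen does not alone set the number. Nothing available accounts for this drop. As far as these compounds go, how a methoxymethyl, an aminomethyl or a plain methyl at that place would read stays open, and so does the reading of a longer hydroxyalkyl chain.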